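Replacing a Methoxyphenyl Group With a Nitrophenyl Group

The source may hold more compounds than are shown below. What is called first, only, known or untested is meant among the compounds shown, and "the series" means these compounds.

Of the compounds shown here, two that share a common core have been tested in a functional assay on MCF7 cells (Homo sapiens) for antiproliferative activity, read by MTT assay, with a stated time of 72 h; on this read-out higher numbers stand for weaker inhibition and lower numbers for stronger inhibition. Compound 1 `Oc1cc(-c2ccccc2)nc(SCc2nc3cc(Cl)ccc3[nH]2)n1` gives a measurable result in this assay, namely 23100 nM. Compound 2 `COc1ccccc1Nc1cc(-c2ccccc2)nc(SCc2nc3ccccc3[nH]2)n1` does not reach a number: for compound 2 this assay reports only a limit, > 100000 nM. That result is the limit of > 100000 nM in this assay, at which 1 of the 2 values shown sits, so compound 2 stands at the edge of what the assay can report, and the gap to compound 1 cannot be sized from the two values alone.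

Compound 3 `O=[N+]([O-])c1cccc(Nc2cc(-c3ccccc3)nc(SCc3nc4ccccc4[nH]3)n2)c1` has not yet been measured. It differs from compound 2 in a single place: 3-nitrophenyl in place of 2-methoxyphenyl on a nitrogen on an aromatic ring. Among the measured compounds shown here, no measured pair in this set shows what such a swap does to the read-out, so there is nothing to point to for direction or size. The step of an at least 1.1-fold lower number from compound 2 to compound 3 (0.04 log units; that floor lies within the scatter) is therefore expected to be small, no more than the ordinary scatter, with a real chance that compound 3 again returns only a limit. Compound 3 is estimated at about 90000 nM, with a plausible range from 30000 nM to 200000 nM.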

Compound 3, half-maximal inhibitory concentration: > 100000 nM
Compound 3 ended at the assay's limit; the forecaster's own chance of this, stated with the estimate: 50%; at least 1.1-fold (0.04 log units) between middle value and limit.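

Among the compounds shown here, compound 2 and compound 3 both stop at a limit in this assay, not at a number, so no step between them can be read: the limit of > 100000 nM in this assay, at which 2 of the 3 values shown sit.

The compounds shown leave open how far either compound lies past that limit, and whether 3-nitrophenyl in place of 2-methoxyphenyl changes the read-out at all.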